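A few compounds are considered here, and "the series" means these few. Any claim that something is new, unique, unknown or untested is made for them only; others in the source may bear on it.

The measured compounds:
compound 1, `CCOC(=O)c1sc2cccc(C)c2c1Nc1cc(OC)c(OC)c(OC)c1`, gives 7390 nM in a functional assay on HL-60 cells (Homo sapiens) for cytotoxicity, read by MTT assay, with a stated time of 72 h; a lower number here means a stronger inhibitor, a higher number a weaker inhibitor;
compound 2, `CCOC(=O)c1sc2ncccc2c1Nc1cc(OC)c(OC)c(OC)c1`, gives 6100 nM in this assay.

Compound 2 sits within the scatter of compound 1, so neither value can be ranked against the other, and the difference between their cores has not been measured as a step of its own. Compound 3, `COC(=O)c1sc2ncccc2c1Nc1cc(OC)c(OC)c(OC)c1`, has not yet been tested. It differs from compound 2 in one place only: hydrogen in place of methyl on a saturated chain carbon bound to an oxygen next to a carbonyl group. The change is small and leaves the rest of the molecule untouched. Among the compounds with values here, no measured pair shows what such a change does in this assay, so the size of the effect can only be estimated; the expectation is for a shift no larger than the scatter, in either direction. Compound 3 is accordingly expected to give about 6000 nM, between 3000 nM and 12000 nM, which means an expected step of a 1.0-fold lower number from compound 2 to compound 3 (0.01 log units; within the scatter).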

Compound 3, half-maximal inhibitory concentration: 2920 nM
Compound 3: middle estimate off by 2.1-fold (0.31 log units), on the high side; measured number outside the range, below it.
By their numbers in this assay, from the lowest: compound 3; then compounds 2 and 1 (each within the scatter of the next).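

Within the data shown here, replacing ethoxycarbonyl with methoxycarbonyl gives the first change here that can be read as a step of its own: in this assay it brings a 2.1-fold lower number from compound 2 to compound 3 (0.32 log units; beyond the scatter), a modest shift beyond the scatter. The result shows that this place on the molecule is not indifferent to the loss of a single methyl, and that, on this core, the shorter chain goes with the lower number. Nothing at hand bears on the reason for this shift.

The compounds shown leave open what a longer chain such as propoxycarbonyl, a free carboxylic acid or an amide would give at this place. They also leave open whether the same change would act alike on the core of compound 1, as the step rests on a single pair.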